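The source may hold more compounds than are shown below. What is called first, only, known or untested is meant among the compounds shown, and "the series" means these compounds.

Notes on the series. For the measured compounds named here, compound 2 `COc1cc2cc(Oc3ccc(NC(=O)Nc4ccc(Cl)c(C(F)(F)F)c4)cc3)c(C)nc2cc1OC` gives 1370 nM in a functional assay on OVCAR-4 cells (Homo sapiens) for inhibition, read by sulforhodamine B assay, with a stated time of 48 h (on this read-out lower numbers stand for stronger inhibition of growth and higher numbers for weaker inhibition of growth), and stands lowest of the two numbers so far; its only neighbour, compound 1 `COc1cc2cc(Oc3ccc(NC(=O)Nc4cccc(C(F)(F)F)c4)cc3)c(C)nc2cc1OC`, gives 2300 nM in this assay, and the gap between them is within the scatter. The next compound, compound 3 `COc1cc2cc(Oc3ccc(NC(=O)Nc4ccc(Cl)c(Cl)c4)cc3)c(C)nc2cc1OC`, differs from compound 2 by chloro in place of trifluoromethyl on an aromatic carbon. Going by the values given here, the one measured step, a 1.7-fold lower number from compound 1 to compound 2 (0.23 log units; within the scatter), concerns the same ring but a different change, the arrival of chloro where hydrogen stood, and it was small; no measured step exchanges trifluoromethyl for chloro. On that basis no step beyond the scatter is expected in this assay for compound 3, in either direction. Compound 3 is therefore estimated at 1500 nM, with a range of 600 nM to 4000 nM. The expected step of a 1.1-fold higher number from compound 2 to compound 3 (0.04 log units; within the scatter) is thus small.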

Compound 3, concentration for 50% growth inhibition: 2670 nM
Compound 3: the middle estimate sits 1.8-fold (0.25 log units) below what was measured; the range from low to high includes it.
By their numbers in this assay, from the lowest: compounds 2, 1 and 3 (each within the scatter of the next).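

In this assay the exchange of trifluoromethyl for chloro, at this carbon ortho to a chloro group, can now be read directly, and it gives a 1.9-fold higher number from compound 2 to compound 3 (0.29 log units; within the scatter). Measured against the 3-(trifluoromethyl)phenyl group, the 3,4-dichlorophenyl group gives a 1.2-fold higher number from compound 1 to compound 3 (0.06 log units; within the scatter), so in these compounds this position carries either trifluoromethyl or chloro with no step beyond the scatter. No evidence is available that bears on this result.

From the compounds shown here alone, whether any group at this position can move the number beyond the scatter remains open, for instance an amine or a carboxylic acid in place of trifluoromethyl or chloro. Also open, going by these compounds, is whether the exchange of trifluoromethyl for chloro reads the same where no neighbouring chloro group is present.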